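Furan to thiophene swap on a shared core

This account rests on a few compounds, and the source may have more. Where it says the series, first, only, none or still open, it means among the compounds named here.

Compound 1 `CC1=C(C(=O)OCC2CC2)C(c2ccco2)NC(=O)N1` is the reference here. In an assay on membranes from HEK293 cells for displacement of a labelled ligand from adenosine receptor A2b (Homo sapiens), read by scintillation counting, with a stated time of 30 min (a lower number here means a stronger inhibitor, a higher number a weaker inhibitor), compound 1 gives 138 nM, the lowest of the two numbers measured. Among the compounds with values here, its companion, compound 2 `CC1=C(C(=O)OCC2CCC2)C(c2ccco2)NC(=O)N1`, carries cyclobutyl in place of cyclopropyl on a saturated chain carbon bound to an oxygen next to a carbonyl group, and in this assay compound 2 gives 561 nM; the single measured step, a 4.1-fold higher number from compound 1 to compound 2 (0.61 log units; beyond the scatter), lies beyond the scatter. Compound 3 `CC1=C(C(=O)OCC2CC2)C(c2ccsc2)NC(=O)N1` is unmeasured and differs from compound 1 by thiophen-3-yl in place of furan-2-yl on a saturated ring carbon. Within the data shown here, no measured step touches the aromatic ring at that position, so the one step on record concerns a different part of the molecule and offers no direct guide. The expectation for compound 3 is therefore a change from compound 1 of no size beyond the scatter, a 1.4-fold higher number from compound 1 to compound 3 (0.16 log units; within the scatter). Compound 3 is estimated at 200 nM in this assay, with a range from 60 nM to 700 nM.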

Compound 3, inhibition constant: 724 nM
For compound 3 the middle estimate is 3.6-fold (0.56 log units) below the measured one; the measured number lies above the stated range.
By their numbers in this assay, from the lowest: compound 1; then compounds 2 and 3 (each within the scatter of the next).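

The step of a 5.2-fold higher number from compound 1 to compound 3 (0.72 log units; beyond the scatter) in this assay shows that the saturated ring carbon is sensitive to which aromatic ring it carries, a point the earlier pair could not address, as it differed only in the cycloalkyl group. Furan-2-yl and thiophen-3-yl have the same counts of heavy atoms and of hydrogen-bond donors and acceptors, and both are five-membered aromatic rings with one hetero atom, so these counts do not account for the step. Nothing available on this pair explains the difference.

Because oxygen gives way to sulfur and the point of attachment moves in the same change, the compounds shown cannot separate the two. As far as these compounds go, how thiophen-2-yl, furan-3-yl or phenyl would read on this carbon remains open, as does whether the cyclobutyl step would carry over to a thiophen-3-yl compound.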